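A few compounds are considered here, and "the series" means these few. Any claim that something is new, unique, unknown or untested is made for them only; others in the source may bear on it.

Measured compounds:
Compound 1, `O=S(=O)(CC1=NCCS1)C1C(c2ccccc2)=NOC1c1ccccc1`, in a functional assay, read by Griess assay, with a stated time of 150 min, tested at 100 ug/mL (on this read-out higher numbers stand for a stronger effect at the one concentration tested and lower numbers for a weaker effect), gives "not active" (no number reported).
Compound 2, `COc1ccc(C2=NN(c3ccccc3)C(c3ccc(C)cc3)C2S(=O)(=O)CC2=NCCS2)cc1`, in this assay gives 50.7%.
Compound 3, `O=S(=O)(CC1=NCCS1)c1n[nH]cc1-c1ccc(Cl)cc1`, in this assay gives "not active" (no number reported).

Compound 1 stands without a number of its own: in this assay compound 1 is reported only as inactive, and compound 3 shares that outcome. Compound 2 alone carries a figure in this assay, so the three measured compounds do not give a ranked set in which compound 1 could be placed; all that can be said is that compound 1 sits at the inactive end while compound 2 shows a clear effect.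

The step from compound 1 to compound 4, `O=S(=O)(CC1=NCCO1)C1C(c2ccccc2)=NOC1c1ccccc1`, is a single exchange: a group of 5 heavy atoms (3 carbon, 1 nitrogen, 1 oxygen; one five-membered non-aromatic ring with 2 hetero atoms) in place of a group of 5 heavy atoms (3 carbon, 1 nitrogen, 1 sulfur; one five-membered non-aromatic ring with 2 hetero atoms), on a saturated chain carbon bound to a sulfonyl sulfur. Within the data shown here, no step between two measured compounds is available to calibrate this exchange, and compound 1 itself supplies no number from which a shift could be counted. Among the measured compounds shown here, with an inactive starting point and no comparable pair, the expected movement in this assay is none beyond the scatter, with the result most likely again reported as inactive or as a small figure.

For compound 4 in this assay the expected value is 10%, within a range of 0% to 30%.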

Compound 4, a percentage reported as activity, at one concentration (the size of the read-out at that concentration, not a potency): 62.8%
The estimate for compound 4 lay 52.8 percentage points below the measured number; the measured number lies above the stated range.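

Among these compounds, no step can be read from compound 1 to compound 4: in this assay compound 1 gives "not active" (no number reported) and compound 4 gives 62.8%, which leaves no pair of numbers to compare. The compounds shown leave open how this exchange of rings would act on a core with a measurable number. Nothing shown bears on the cause of this result.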